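The source may report more compounds than this note shows. Statements on the series, on what has been measured and on what is new or still open speak of the compounds shown alone.

In a functional assay on MGC-803 cells (Homo sapiens) for cytotoxicity, read by MTT assay, with a stated time of 48 h (on this read-out higher numbers stand for weaker inhibition and lower numbers for stronger inhibition), compound 3 `CC1=NN(C(=O)CCc2ccccc2)C(c2cc(Br)ccc2O)C1` gives 21200 nM and compound 2 `CC1=NN(C(=O)CCl)C(c2cc(Br)ccc2O)C1` gives 13500 nM, so the two lie within the scatter of each other. Compound 1 `CC1=NN(C(=O)COc2ccc(Cl)cc2)C(c2ccccc2O)C1`, which also carries 4-chlorophenoxy, gives "not active" (no number reported). Compound 4 `CC1=NN(C(=O)COc2ccc(Cl)cc2)C(c2cc(Br)ccc2O)C1` differs from compound 3 at one place: 4-chlorophenoxy in place of benzyl on a saturated chain carbon bound to a carbonyl carbon. Among the compounds with values here, the only measured step at this place is a 1.6-fold higher number from compound 2 to compound 3 (0.20 log units; within the scatter), which stays within the scatter. On that step, no change beyond the scatter is expected in this assay, although compound 1 at "not active" (no number reported) leaves open a loss of measurable activity. The expected change is a 1.2-fold lower number from compound 3 to compound 4 (0.07 log units; within the scatter). For compound 4 the estimated value is 18000 nM, with an expected range of 7000 nM to 45000 nM.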

Compound 4, half-maximal inhibitory concentration: 23600 nM
The estimate for compound 4 lay 1.3-fold (0.12 log units) below the measured number; low and high end bracket the measured number.
By their numbers in this assay, from the lowest: compounds 2, 3 and 4 (each within the scatter of the next).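

In this assay, a third group on a saturated chain carbon bound to a carbonyl carbon again stays within the scatter, with a 1.1-fold higher number from compound 3 to compound 4 (0.05 log units; within the scatter) and a 1.7-fold higher number from compound 2 to compound 4 (0.24 log units; within the scatter), so chloro, benzyl and 4-chlorophenoxy are not told apart at this place. 4-Chlorophenoxy also allows a measurable number on this core: compound 4 gives 23600 nM, whereas compound 1, on its own core, gives "not active" (no number reported). No evidence at hand bears on this result. The compounds shown leave open whether an amine or a carboxylic acid at this place would move the number beyond the scatter.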